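The source may report more compounds than this note shows. Statements on the series, on what has been measured and on what is new or still open speak of the compounds shown alone.

Measured so far:
Compound 1, `CC(C)C(=O)OCCc1c(-c2ccccc2Cl)c2cc(Cl)ccc2[nH]c1=O`, in an ADME assay on HepG2 2.2.15 cells (Homo sapiens) for cytotoxicity (on this read-out higher numbers stand for lower toxicity in this test and lower numbers for higher toxicity in this test), gives 62000 nM.
Compound 2, `O=C(OCCc1c(-c2ccccc2Cl)c2cc(Cl)ccc2[nH]c1=O)C1CCCCC1`, gives 38000 nM.

Compound 2 sits right beside compound 1 on this read-out: the step of a 1.6-fold lower number from compound 1 to compound 2 (0.21 log units; within the scatter) is within the scatter, so the two compounds are not told apart by this test, and both show cytotoxicity only at high concentrations. Compound 3, `O=C(OCCc1c(-c2ccccc2Cl)c2cc(Cl)ccc2[nH]c1=O)c1ccco1`, has not been measured. It differs from compound 2 in one place: furan-2-yl in place of cyclohexyl on a carbonyl carbon. Among the measured compounds shown here, the only measured step that touches this place is a 1.6-fold lower number from compound 1 to compound 2 (0.21 log units; within the scatter), where one carbon-only group replaced another on the carbonyl carbon, and that step stayed within the scatter. For the measured compounds named here, no measured step brings a furan-2-yl, or any aromatic ring, onto the carbonyl carbon, so the data give no direction for this change. Compound 3 is therefore expected to stay close to compound 2, with an expected step of a 1.2-fold higher number from compound 2 to compound 3 (0.07 log units; within the scatter) that should not go beyond the scatter. For compound 3 the estimated value in this assay is 45000 nM, with a range from 20000 nM to 100000 nM.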

Compound 3, half-maximal cytotoxic concentration: 98000 nM
Beside the measured number, compound 3's estimate is 2.2-fold (0.34 log units) below it, within the range that was stated.
By their numbers in this assay, from the lowest: compounds 2, 1 and 3 (each within the scatter of the next, the first and the last beyond it).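

In this assay the carbonyl carbon now shows its first step beyond the scatter: a 2.6-fold higher number from compound 2 to compound 3 (0.41 log units; beyond the scatter) when furan-2-yl, a five-membered aromatic ring with one hetero atom, replaces cyclohexyl, a six-membered non-aromatic ring of carbon only. Set against the isopropyl group, the same furan-2-yl gives a 1.6-fold higher number from compound 1 to compound 3 (0.20 log units; within the scatter) and so is not told apart from it, which means that the group at this position can move the read-out modestly, but only compound 2 and compound 3 are separated, while compound 1 cannot be separated from either. Nothing measured here offers an explanation for the step between the two rings.

A phenyl ring or a thiophene ring on the same carbonyl carbon would help to show whether this step belongs to aromatic rings in general or to furan-2-yl in particular. From the compounds shown here alone, it also remains open how an amine, a carboxylic acid or a longer carbon chain at this position would read on the same test, and whether any such group would take the numbers further from those of compound 2.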